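Anilide replaces isobutylamide in a series without measurable cytotoxicity

The source may report more compounds than this note shows. Statements on the series, on what has been measured and on what is new or still open speak of the compounds shown alone.

Compound 3 `C=CC1=C(C(=O)NCC(C)C)C(c2ccc(F)cc2)OC1` carries an isobutylamide on the shared core. In a functional assay on A549 cells (Homo sapiens) for cytotoxicity, read by MTT assay, with a stated time of 24 h (on this read-out lower numbers stand for stronger inhibition and higher numbers for weaker inhibition), compound 3 gives > 100000 nM, which is a limit of the assay and not a number. Its two neighbours stand the same way. Compound 1 `C=CC1=C(C(=O)NCc2ccc(C)cc2)C(c2ccc(F)cc2)OC1` gives > 100000 nM in this assay, again a limit. Compound 2 `C=CC1=C(C(=O)NCc2ccc(Cl)cc2)C(c2ccc(F)cc2)OC1` gives > 100000 nM, also a limit. All three therefore sit at the limit of > 100000 nM in this assay, at which 3 of the 3 values shown sit, and the three steps among them, a step that the two limits leave unreadable from compound 1 to compound 2, a step that the two limits leave unreadable from compound 1 to compound 3 and a step that the two limits leave unreadable from compound 2 to compound 3, cannot be read in size.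

Compound 4 `C=CC1=C(C(=O)Nc2ccc(C)cc2)C(c2ccc(F)cc2)OC1` differs from compound 3 by 4-methylphenyl in place of isobutyl on an amide-type nitrogen. The nearest measured comparisons are the steps that lead from compound 1 and compound 2 to compound 3, each trading an aryl-bearing chain for a branched alkyl chain on the amide nitrogen, and both remain unreadable between the two limits. Among the measured compounds shown here, no measured step in this assay shows any change that can be read, and compound 4 keeps the same core and the same amide linkage. Compound 4 is therefore expected to stay at the limit as well, with a step that the limit leaves unreadable from compound 3 to compound 4 meaning no movement that can be read. The estimate for compound 4 is 150000 nM, expected to lie between 60000 nM and 400000 nM.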

Compound 4, half-maximal inhibitory concentration: > 100000 nM
Compound 4: a limit, no number; the forecaster's own chance of this, stated with the estimate: 85%; the middle value is on the limit's open side.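

In this assay, among the compounds shown here, compound 4 gives > 100000 nM, a limit of the assay and not a number, so no step from compound 1, compound 2 or compound 3 to compound 4 can be read in size. The series stays where it stood: the limit of > 100000 nM in this assay, at which 4 of the 4 values shown sit.

The compounds shown leave open which change on the shared core, if any, would give a measurable value in this assay.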